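Compound 1 and a dimethoxyphenyl exchange

The source may report more compounds than this note shows. Statements on the series, on what has been measured and on what is new or still open speak of the compounds shown alone.

Values in an ADME assay on NIH3T3 cells (Mus musculus) for inhibition, read by sulforhodamine B assay, with a stated time of 48 h (on this read-out higher numbers stand for weaker inhibition of growth and lower numbers for stronger inhibition of growth), for the measured compounds
Compound 1 `O=C(NNC(=O)c1ccc2[nH]c(-c3ccc([N+](=O)[O-])o3)nc2c1)c1ccccc1` gives 31.3 ug/mL
Compound 2 `COc1cc(C(=O)NNC(=O)c2ccc3[nH]c(-c4ccc([N+](=O)[O-])s4)nc3c2)cc(OC)c1OC` gives 31.3 ug/mL
Compound 3 `O=C(O)c1ccc2[nH]c(-c3ccc([N+](=O)[O-])o3)nc2c1` gives 62.5 ug/mL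

Compound 1 at 31.3 ug/mL stands level with compound 2, and compound 3 at 62.5 ug/mL lies within the scatter of it. Compound 4 `COc1ccc(C(=O)NNC(=O)c2ccc3[nH]c(-c4ccc([N+](=O)[O-])o4)nc3c2)cc1OC`, not yet measured, carries 3,4-dimethoxyphenyl in place of phenyl on a carbonyl carbon and is otherwise the same as compound 1. Going by the values given here, no two measured compounds differ in only one place, so the data offer no direct precedent. Compound 2, which also carries methoxy groups, stands at 31.3 ug/mL in this assay on a different core, so no step beyond the scatter is expected in either direction. The expected result is no change at the digits printed from compound 1 to compound 4 (within the scatter) and stays within the scatter. For compound 4 an estimate of 31.3 ug/mL is expected to hold, with 15.6 ug/mL and 62.5 ug/mL as the ends of its range.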

Compound 4, concentration for 50% growth inhibition: 31.3 ug/mL
For compound 4 middle estimate and measured number coincide at the digits printed, within the range that was stated.
By their numbers in this assay, from the lowest: compounds 1, 2, 4 and 3 (each within the scatter of the next).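

Going by these compounds alone, on the carbonyl carbon whose other neighbour is an amide-type nitrogen, 3,4-dimethoxyphenyl in place of phenyl gives no change at the digits printed from compound 1 to compound 4 (within the scatter) in this assay and provides the first comparison of compounds differing in one place. This position therefore accepts the two methoxy groups on the core of compound 1 without a step beyond the scatter. No measurement is available to explain this result. 

On these data alone, whether an amine or a carboxylic acid in place of phenyl on this carbonyl carbon would hold the same level remains open. So does the effect of a longer chain there.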